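Compound 4: a larger ring group on the same core

A few compounds are considered here, and "the series" means these few. Any claim that something is new, unique, unknown or untested is made for them only; others in the source may bear on it.

Values in a physicochemical assay for lipophilicity, read by LC-MS, in phosphate buffer, measured as octanol-water partition, at pH 7.4, tested at 66.7 uM (a lower number here means a more polar compound, a higher number a more lipophilic compound), are as follows:
Compound 1 `Cc1ccc(-c2ccnc(Nc3ccc(N4CCN(C)CC4)c(C(F)(F)F)c3)n2)cc1` gives > 5.85 (a limit, not a number)
Compound 2 `CN1CCN(c2ccc(Nc3nccc(-c4ccccc4)n3)cc2C(F)(F)F)CC1` gives 4.8 (a number)
Compound 3 `CN1CCN(c2ccc(Nc3nccc(-c4cccnc4)n3)cc2C(F)(F)F)CC1` gives 3.53 (a number)

Going by the values given here, only two of these values are true numbers, and compound 3 holds the lower one, with compound 2 above it. Compound 4 `CN1CCN(c2ccc(Nc3nccc(-c4cnn5ncccc45)n3)cc2C(F)(F)F)CC1` has not yet been measured. It differs from compound 3 by a single swap: a group of 9 heavy atoms (6 carbon, 3 nitrogen; one five-membered aromatic ring with 2 hetero atoms, one six-membered aromatic ring with 2 hetero atoms) in place of a group of 6 heavy atoms (5 carbon, 1 nitrogen; one six-membered aromatic ring with 1 hetero atom), on an aromatic carbon (next to the ring nitrogen).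

Among the compounds with values here, no measured step matches this swap, but two come close. Pyridin-3-yl in place of phenyl gave a number 1.27 log units lower from compound 2 to compound 3 (beyond the scatter) and hydrogen in place of methyl gave a number at least 1.05 log units lower from compound 1 to compound 2 (beyond the scatter) (this one starts from a limit). Taken together, they appear as a number at least 2.32 log units lower from compound 1 to compound 3 (beyond the scatter) (again from a limit). Both lowered the number, one by gaining ring nitrogen and the other by losing carbon. The entering group gains both carbon and nitrogen, so these two precedents pull in opposite directions. In this assay no step beyond the scatter is therefore expected, in either direction.

The expected change is a number 0.07 log units higher from compound 3 to compound 4 (within the scatter) (an estimate). For compound 4 the estimated value is 3.6 (expected range 3 to 4.2).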

Compound 4, distribution coefficient: 3.71
The estimate for compound 4 lay 0.11 log units below the measured number; measured number inside the range.
By their numbers in this assay, from the lowest: compounds 3 and 4 (each within the scatter of the next); then compound 2. At a limit, above all of these: compound 1.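

In this assay, putting the larger group, with its five-membered and six-membered aromatic rings, in place of pyridin-3-yl gives a number 0.18 log units higher from compound 3 to compound 4 (within the scatter), so on this aromatic carbon the added heavy atoms bring no change beyond the scatter. Set against the all-carbon phenyl ring, the same group gives a number 1.09 log units lower from compound 2 to compound 4 (beyond the scatter), which places compound 4 with compound 3, the two compounds shown whose group carries ring nitrogen, and apart from compound 2. The step from the 4-methylphenyl group starts from a limit, not a number, and so reads only as a number at least 2.14 log units lower from compound 1 to compound 4 (beyond the scatter), with that limit being: the limit of > 5.85 in this assay, at which 1 of the 4 values shown sits.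

The compounds shown change ring size and ring nitrogen count together, so it stays open which of the two goes with the number in this assay. Also open, on these data alone, is how a group of a different kind on this carbon, such as an amine or a carboxylic acid, would read against these aromatic rings.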